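Swapping a Benzoyl for a Cyano on an Indole Sulfone

This account rests on a few compounds, and the source may have more. Where it says the series, first, only, none or still open, it means among the compounds named here.

Of the compounds shown here, two have been measured so far. Compound 1 `COc1ccc(-c2[nH]c3ccccc3c2/C=C(\C#N)S(=O)(=O)c2ccccc2)cc1` gives 803 nM in a functional assay on A549 cells (Homo sapiens) for inhibition, read by sulforhodamine B assay, with a stated time of 48 h; on this read-out higher numbers stand for weaker inhibition of growth and lower numbers for stronger inhibition of growth. Compound 2 `O=C(/C(=C\c1c(-c2ccccc2)[nH]c2ccccc12)S(=O)(=O)c1ccccc1)c1ccccc1` gives 35000 nM in this assay, the highest of the two numbers and a markedly weaker result than compound 1, a gap well beyond the usual scatter.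

Compound 3 `N#C/C(=C\c1c(-c2ccccc2)[nH]c2ccccc12)S(=O)(=O)c1ccccc1` has not yet been tested. It differs from compound 2 in a single place: cyano in place of benzoyl on a double-bonded chain carbon bound to a double-bonded chain carbon and a sulfonyl sulfur.

Going by the values given here, the step from compound 2 to compound 3 is expected to bring a clearly lower number in this assay, meaning stronger inhibition of growth, because the only other measured compound, compound 1, gives 803 nM. The estimated step is a 23-fold lower number from compound 2 to compound 3 (1.37 log units; beyond the scatter). Compound 3 is accordingly expected to give about 1500 nM in this assay, with a plausible range from 300 nM to 8000 nM.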

Compound 3, concentration for 50% growth inhibition: 3700 nM
Estimate against measurement, compound 3: 2.5-fold (0.39 log units) below; measured number inside the range.
By their numbers in this assay, from the lowest: compound 1; then compound 3; then compound 2.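

In this assay, changing only the group on the double-bonded chain carbon bound to a double-bonded chain carbon and a sulfonyl sulfur gives a 9.5-fold lower number from compound 2 to compound 3 (0.98 log units; beyond the scatter). This step is beyond the scatter and means stronger inhibition of growth, so with the rest of the molecule held constant, cyano outperforms benzoyl at this position. The second single change, hydrogen in place of methoxy on an aromatic carbon, gives a 4.6-fold higher number from compound 1 to compound 3 (0.66 log units; beyond the scatter), also beyond the scatter, which shows that the methoxy compound inhibits growth more strongly than its counterpart without that group. Nothing available explains why either change shifts the number.

The compounds shown leave open whether another group at the chain carbon, such as a methyl ester or a carboxylic acid, would match cyano or surpass it. They also do not show whether the gain seen with methoxy extends to other groups on the aromatic carbon, such as an amine or a longer ether chain.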